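The source may report more compounds than this note shows. Statements on the series, on what has been measured and on what is new or still open speak of the compounds shown alone.

Three compounds that share one core and differ only in the aromatic group hanging from the chain have been measured in a functional assay on A549 cells (Homo sapiens) for antiproliferative activity, read by MTT assay, with a stated time of 72 h; on this read-out higher numbers stand for weaker inhibition and lower numbers for stronger inhibition. Compound 1 `NC1=NC2(CCOCC2)N(OCCCOc2cccc(Cl)c2)C(N)=N1` gives 150 nM and stands lowest of the three numbers, which on this read-out means the strongest inhibition. Compound 2 `NC1=NC2(CCOCC2)N(OCCCOc2ccc(Cl)c(Cl)c2)C(N)=N1` gives 790 nM, and compound 3 `Cc1ccc(OCCCON2C(N)=NC(N)=NC23CCOCC3)cc1` gives 1060 nM.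

The next step goes from compound 1 to compound 4 `NC1=NC2(CCOCC2)N(OCCCOc2ccc(Br)cc2)C(N)=N1`, and the change is 4-bromophenyl in place of 3-chlorophenyl on an oxygen on a saturated carbon.

Among the compounds with values here, two measured steps bear on this. Adding a second chloro to the ring of compound 1 produced a 5.3-fold higher number from compound 1 to compound 2 (0.72 log units; beyond the scatter). Replacing the 3-chlorophenyl of compound 1 with 4-methylphenyl produced a 7.1-fold higher number from compound 1 to compound 3 (0.85 log units; beyond the scatter). Within the data shown here, in both cases the number rose beyond the scatter, so a 4-bromophenyl group, which also carries its halogen at a position that differs from the one in compound 1, is expected to give a weaker inhibition than compound 1, by a modest amount rather than none.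

Compound 4 is therefore expected to give 700 nM in this assay, with a likely range from 250 nM to 2000 nM, which means an expected step of a 4.7-fold higher number from compound 1 to compound 4 (0.67 log units; beyond the scatter).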

Compound 4, half-maximal inhibitory concentration: 280 nM
Beside the measured number, compound 4's estimate is 2.5-fold (0.40 log units) above it; the range from low to high includes it.
By their numbers in this assay, from the lowest: compounds 1 and 4 (each within the scatter of the next); then compounds 2 and 3 (each within the scatter of the next).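

In this assay, 4-bromophenyl can take the place of 3-chlorophenyl on this chain with no change that stands clear of the scatter, a 1.9-fold higher number from compound 1 to compound 4 (0.27 log units; within the scatter), so not every replacement of that ring group costs activity. The ring group still matters, since bromo in place of methyl on an aromatic carbon gives a 3.8-fold lower number from compound 3 to compound 4 (0.58 log units; beyond the scatter), and exchanging 3,4-dichlorophenyl for 4-bromophenyl gives a 2.8-fold lower number from compound 2 to compound 4 (0.45 log units; beyond the scatter), both beyond the scatter. No measurement is at hand that explains why these ring groups differ.

The change from compound 1 to compound 4 swaps the halogen and its place on the ring together, so the compounds shown cannot separate the two, and 4-chlorophenyl or 3-bromophenyl would be needed to tell them apart. Also open, from the compounds shown here alone, is how the ring would respond to an amine, a carboxylic acid or a nitrile in place of the halogen, and how these results would hold with a longer chain between the core and the ring.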